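Amino-acid piperazine amides of an aryl ketone series

This account rests on a few compounds, and the source may have more. Where it says the series, first, only, none or still open, it means among the compounds named here.

Measured so far:
compound 1, `CCCCCC(=O)c1ccc(OCCCN2CCN(C(=O)[C@@H](C)NC(=O)OC(C)(C)C)CC2)cc1`, an assay for binding affinity to histamine H2 receptor (Homo sapiens) (a lower number here means a stronger inhibitor, a higher number a weaker inhibitor), 10700 nM
compound 2, `CC(C)N[C@H](C)C(=O)N1CCN(CCCOc2ccc(C(=O)C3CC3)cc2)CC1`, this assay 50100 nM
compound 3, `CCCCCC(=O)c1ccc(OCCCN2CCN(C(=O)[C@H](CC(C)C)NC(=O)OC(C)(C)C)CC2)cc1`, this assay 3470 nM

Compound 2 has the highest number of the three in this assay; its value lies beyond the scatter from compound 1 and still further from compound 3, so it is the weakest of the measured set. Compound 1 and compound 3 share the same core and differ only in the amino-acid side chain, where the larger chain goes with the lower number; with just these two no firm pattern can be claimed.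

Compound 4, `N[C@H](CC1CCCCC1)C(=O)N1CCN(CCCOc2ccc(C(=O)C3CC3)cc2)CC1`, has not yet been measured. It keeps the core of compound 2 and carries 1-amino-2-cyclohexylethyl in place of 1-(isopropylamino)ethyl on a carbonyl carbon. For the measured compounds named here, no measured pair isolates this change, so its effect is estimated from the side-chain comparison of compound 1 and compound 3 only. The expected step is downward and beyond the scatter: the estimate for compound 4 means a 3.3-fold lower number from compound 2 to compound 4 (0.52 log units; beyond the scatter) in this assay. Compound 4 is therefore expected to give about 15000 nM, plausibly between 4000 nM and 60000 nM.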

Compound 4, inhibition constant: 20400 nM
The estimate for compound 4 lay 1.4-fold (0.13 log units) below the measured number; measured number inside the range.
By their numbers in this assay, from the lowest: compound 3; then compounds 1 and 4 (each within the scatter of the next); then compound 2.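

In this assay, for the compounds shown here, 1-amino-2-cyclohexylethyl in place of 1-(isopropylamino)ethyl on a carbonyl carbon gives a 2.5-fold lower number from compound 2 to compound 4 (0.39 log units; beyond the scatter), the only step so far that isolates a change at this position. The step is modest but beyond the scatter, so this position on the core of compound 2 tolerates a six-membered non-aromatic ring of carbon only without a rise in the number, while the counts of hydrogen-bond donors and acceptors in the group stay the same. Nothing available accounts for the step.

From the compounds shown here alone, the exchange alters both the isopropyl on the amine and the side chain at once, so the share of each in the step remains open. Also open, going by these compounds, is how a phenyl ring or a longer carbon chain in place of the cyclohexyl ring would compare.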